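Acetyl for chloro on the anilide of compound 1

A few compounds are considered here, and "the series" means these few. Any claim that something is new, unique, unknown or untested is made for them only; others in the source may bear on it.

Measured compounds in a functional assay on EC9706 cells (Homo sapiens) for cytotoxicity, read by MTT assay, with a stated time of 72 h; a higher number here means a weaker inhibitor, a lower number a stronger inhibitor:
- compound 1, `O=C(CSC(=S)N[C@H]1CCOC1=O)Nc1ccc(Cl)cc1`, gives > 128000 nM, a limit of the assay.
- compound 2, `O=C(CSC(=S)N[C@H]1CCOC1=O)Nc1ccc(Cl)cc1Cl`, gives > 128000 nM, again a limit.
- compound 3, `O=C(CSC(=S)N[C@H]1CCOC1=O)Nc1cccc(C(F)(F)F)c1`, gives 79700 nM.

Compound 1 stands at the limit of this assay, with no number of its own; it shares that standing with one further compound, as the limit of > 128000 nM in this assay, at which 2 of the 3 values shown sit, shows. Among the compounds with values here, the one single-point step among the measured compounds, a step that the two limits leave unreadable from compound 1 to compound 2, is left unreadable by the two limits. Compound 3 differs from compound 1 in two places, so its value only shows that a compound of this core can return a readable, weak number.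

Compound 4, `CC(=O)c1ccc(NC(=O)CSC(=S)N[C@H]2CCOC2=O)cc1`, is the next entry. It differs from compound 1 by acetyl in place of chloro on an aromatic carbon. Within the data shown here, no measured step covers this change: the only step available is unreadable, and compound 3 is not a single-point neighbour. The expectation for this assay therefore rests on where the series sits, which is at or near the limit, and the expected step of an at least 1.0-fold lower number from compound 1 to compound 4 (0.02 log units; that floor lies within the scatter) is small and of no settled direction. Compound 4 is expected at 120000 nM, with a range from 40000 nM to 400000 nM, and a limit rather than a number is the more likely report.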

Compound 4, half-maximal inhibitory concentration: > 128000 nM
Compound 4: only a limit was reported; the forecaster's own chance of this, stated with the estimate: 60%; middle value at least 1.0-fold (0.02 log units) away from the limit.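

No step can be read from compound 1 to compound 4 for acetyl in place of chloro, because both compounds are reported only as a limit: the limit of > 128000 nM in this assay, at which 3 of the 4 values shown sit.

The compounds shown leave open whether this change alters cytotoxicity at all, and how any single change on the shared core moves a readable value.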